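Thiourea chalcone glycosides: cytotoxicity on Vero cells

A few compounds are considered here, and "the series" means these few. Any claim that something is new, unique, unknown or untested is made for them only; others in the source may bear on it.

Measured compounds and their values in an ADME assay on Vero cells (Chlorocebus sabaeus) for cytotoxicity, read by resazurin assay, with a stated time of 2 days; on this read-out lower numbers stand for higher toxicity in this test and higher numbers for lower toxicity in this test:
compound 1, `O=C(/C=C/c1cccc(NC(=S)Nc2ccccc2)c1)C[C@@H]1O[C@H](CO)[C@@H](O)[C@H](O)[C@H]1O`, 371000 nM
compound 2, `CC(=O)OC[C@H]1O[C@@H](CC(=O)/C=C/c2cccc(NC(=S)Nc3ccccc3)c2)[C@H](OC(C)=O)[C@@H](OC(C)=O)[C@@H]1OC(C)=O`, 337000 nM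
compound 3, `COc1cc([N+](=O)[O-])ccc1NC(=S)Nc1cccc(/C=C/C(=O)C[C@@H]2O[C@H](COC(C)=O)[C@@H](OC(C)=O)[C@H](OC(C)=O)[C@H]2OC(C)=O)c1`, 559000 nM

Compound 1 and compound 2 share the same thiourea chalcone arm but carry different sugar portions; the difference between the two cores is not broken down here, and their values lie within the scatter of each other. From compound 2 to compound 3 the change is 2-methoxy-4-nitrophenyl in place of phenyl on an amide-type nitrogen, and in this assay it gave a 1.7-fold higher number from compound 2 to compound 3 (0.22 log units; within the scatter). The same kind of change is now made on the free-sugar core: compound 4, `COc1cc([N+](=O)[O-])ccc1NC(=S)Nc1cccc(/C=C/C(=O)C[C@@H]2O[C@H](CO)[C@@H](O)[C@H](O)[C@H]2O)c1`, differs from compound 1 by 2-methoxy-4-nitrophenyl in place of phenyl on an amide-type nitrogen, at a place whose neighbourhood reads the same in both pairs.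

Within the data shown here, since the only measured example of this change, from compound 2 to compound 3, stayed within the scatter, a step of similar size is expected for compound 4 in this assay, namely a 1.3-fold higher number from compound 1 to compound 4 (0.13 log units; within the scatter). Compound 4 is therefore estimated at 500000 nM, with a likely range from 250000 nM to 1000000 nM.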

Compound 4, half-maximal cytotoxic concentration: 203000 nM
The estimate for compound 4 lay 2.5-fold (0.39 log units) above the measured number; measured number below the stated range.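

On the free-sugar core, 2-methoxy-4-nitrophenyl in place of phenyl on an amide-type nitrogen gave a 1.8-fold lower number from compound 1 to compound 4 (0.26 log units; within the scatter) in this assay. Set beside the earlier pair, the change did not carry over from one core to the other with the same direction, and the gap between the two steps is larger than either step taken alone: the same change on two cores in this assay, a 1.7-fold higher number (0.22 log units; within the scatter) from compound 2 to compound 3 and a 1.8-fold lower number (0.26 log units; within the scatter) from compound 1 to compound 4, 3.0-fold (0.48 log units) apart, beyond the scatter of two such steps. This shows that, for these two pairs, the outcome of the change differs with the core, but each step on its own stays within the scatter, and two pairs show neither which part of the cores goes with the gap nor whether it extends to other replacements.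

The compounds shown leave open whether the methoxy or the nitro group accounts for the gap, which a phenyl carrying only one of them could separate. They also leave open whether an amine in place of the nitro group would give steps that agree across the two cores.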